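A few compounds are considered here, and "the series" means these few. Any claim that something is new, unique, unknown or untested is made for them only; others in the source may bear on it.

Working notes on the series. Going by the values given here, in a functional assay on the whole organism (artery, strain albino) with Rattus norvegicus as the target, with a stated time of 600 min, at a dose of 10 mg/kg by the oral route (on this read-out higher numbers stand for more inhibition at the one dose given (going by the name of the read-out) and lower numbers for less inhibition), compound 2 `COc1ccc(C2N=C(SCc3cccc(Cl)c3)NC(C)=C2C(=O)Nc2ccc(F)cc2)cc1OC` gives 17.4%, the higher of the two numbers so far; compound 1 `COc1ccc(C2N=C(SCc3ccccc3)NC(C)=C2C(=O)Nc2ccc(F)cc2)cc1OC` gives 3.1%. Among the compounds with values here, the only measured step, a number 14.3 percentage points higher from compound 1 to compound 2 (beyond the scatter), concerns putting chloro onto an aromatic carbon, not moving a chloro already there. Compound 3 `COc1ccc(C2N=C(SCc3ccc(Cl)cc3)NC(C)=C2C(=O)Nc2ccc(F)cc2)cc1OC` differs from compound 2 by 4-chlorophenyl in place of 3-chlorophenyl on a saturated chain carbon bound to a sulfur. Within the data shown here, no measured step bears directly on this change, so no direction is expected; the expected step of a number 1.4 percentage points lower from compound 2 to compound 3 (within the scatter) is none beyond the scatter. Compound 3 is therefore estimated at 16%, with a range of 2% to 32%.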

Compound 3, a percentage reported as inhibition, in the whole organism at one dose (the size of the read-out at that dose, not a potency): 26.7%
For compound 3 the middle estimate is 10.7 percentage points below the measured one, and the stated range covers the measured number.
By their numbers in this assay, from the lowest: compound 1; then compounds 2 and 3 (each within the scatter of the next).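

In this assay, moving the chlorine from 3-chlorobenzyl to 4-chlorobenzyl gives a number 9.3 percentage points higher from compound 2 to compound 3 (within the scatter), so this read-out does not separate the two placements. Chloro in place of hydrogen on an aromatic carbon now gives a number 23.6 percentage points higher from compound 1 to compound 3 (beyond the scatter) as well, and both chloro placements stand beyond the scatter from the unsubstituted benzyl of compound 1. Nothing available accounts for these numbers.

On these data alone, whether the gain belongs to chloro specifically stays open, since no bromo, methoxy or nitrile stands at these ring positions. A longer chain between the sulfur and the ring also remains untested in the compounds shown.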